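Working notes: from compound 3 to compound 4

The source may hold more compounds than are shown below. What is called first, only, known or untested is meant among the compounds shown, and "the series" means these compounds.

compound 1 `CC(=O)N[C@@H]1CCC[C@H](C(=O)Nc2cc(-c3cnc(C)n3C(C)C)ccn2)C1` gives 660000 nM
compound 2 `CC(=O)N[C@@H]1CCC[C@H](C(=O)Nc2cc(-c3cnn4c3CCCC4)ccn2)C1` gives 730000 nM
compound 3 `CC(=O)N[C@@H]1CCC[C@H](C(=O)Nc2cc(-c3cnc4n3CCCC4)c(Cl)cn2)C1` gives 600000 nM

In a physicochemical assay for solubility, in phosphate buffer, at pH 7.4 (a higher number here means a more soluble compound, a lower number a less soluble compound), the three numbers cannot be told apart. Compound 3 at 600000 nM lies within the usual scatter of both compound 1 and compound 2.

The next compound is compound 4 `CC(=O)N[C@@H]1CCC[C@H](C(=O)Nc2cc(-c3cnn4c3CCC4)c(Cl)cn2)C1` and the change is a group of 8 heavy atoms (6 carbon, 2 nitrogen; one five-membered non-aromatic ring with 1 hetero atom, one five-membered aromatic ring with 2 hetero atoms) in place of a group of 9 heavy atoms (7 carbon, 2 nitrogen; one five-membered aromatic ring with 2 hetero atoms, one six-membered non-aromatic ring with 1 hetero atom), on an aromatic carbon with the group ortho to a chloro group and opposite the ring nitrogen. For the measured compounds named here, no measured pair shows this exact exchange. Going by the values given here, only one measured step bears on it, another exchange of groups on an aromatic carbon: a 1.1-fold higher number from compound 1 to compound 2 (0.04 log units; within the scatter) and so nothing beyond the scatter. All three measured compounds also sit close together, so no change in this assay beyond the scatter is expected, in either direction. The expected step is a 1.1-fold higher number from compound 3 to compound 4 (0.03 log units; within the scatter) on this thin evidence. The estimate for compound 4 is 640000 nM (expected range 340000 nM to 1100000 nM).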

Compound 4, solubility: 160000 nM
Compound 4: the middle estimate sits 4.0-fold (0.60 log units) above what was measured; measured number below the stated range.
By their numbers in this assay, from the lowest: compound 4; then compounds 3, 1 and 2 (each within the scatter of the next).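

In this assay, the position on the aromatic carbon ortho to a chloro group and opposite the ring nitrogen responds to the group it carries: a 3.8-fold lower number from compound 3 to compound 4 (0.57 log units; beyond the scatter) is the first step shown that lies beyond the scatter. For the compounds shown here, the only earlier step, a 1.1-fold higher number from compound 1 to compound 2 (0.04 log units; within the scatter), was another group exchange on an aromatic carbon and stayed within the scatter, so it gave no sign that such an exchange could matter. No measurement shown accounts for the new step.

Compound 3 and compound 4 differ in both the size of the non-aromatic ring and the placing of the nitrogens within the group, and these two changes cannot be separated here. On these data alone, it also remains open whether the step persists without the chloro group, and how an amine or a carboxylic acid on the five-membered non-aromatic ring would read in this assay.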